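A Larger Aryl Group in Place of Bromine

This account rests on a few compounds, and the source may have more. Where it says the series, first, only, none or still open, it means among the compounds named here.

Compound 1 `O=C(CCc1cccc2c1B(O)OC2)Nc1ccc(I)cc1` gives 33000 nM.
Compound 2 `O=C(CCc1cccc2c1B(O)OC2)Nc1cccc(Br)c1` gives 720 nM.
Compound 3 `Cc1ccc(NC(=O)CCc2cccc3c2B(O)OC3)cc1Br` gives 870 nM.

In a functional assay on MDA-MB-231 cells (Homo sapiens) for antiproliferative activity, read by MTT assay, with a stated time of 72 h (on this read-out higher numbers stand for weaker inhibition and lower numbers for stronger inhibition), compound 2 stands at the lowest number of the three. Compound 3 sits within the scatter of it (a 1.2-fold higher number from compound 2 to compound 3 (0.08 log units; within the scatter)), while compound 1 lies far above (a 46-fold lower number from compound 1 to compound 2 (1.66 log units; beyond the scatter)). Compound 4 `O=C(CCc1cccc2c1B(O)OC2)Nc1cccc(-c2cccc(C(F)(F)F)c2)c1` arises from compound 2 by one change: 3-(trifluoromethyl)phenyl in place of bromo on an aromatic carbon. For the measured compounds named here, no measured step swaps a halogen for an aromatic group at this place; the step from compound 2 to compound 3 shows that a small addition on this ring stays within the scatter, and the step from compound 1 to compound 2 concerns a different halogen at a different place. The expected step is therefore a 1.4-fold higher number from compound 2 to compound 4 (0.14 log units; within the scatter), with wide uncertainty. Compound 4 is estimated at 1000 nM, between 250 nM and 4000 nM.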

Compound 4, half-maximal inhibitory concentration: 410 nM
Compound 4: the middle estimate sits 2.4-fold (0.39 log units) above what was measured; measured number inside the range.
By their numbers in this assay, from the lowest: compounds 4, 2 and 3 (each within the scatter of the next, the first and the last beyond it); then compound 1.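

Replacing bromo, a single heavy atom, with 3-(trifluoromethyl)phenyl, which has 10 heavy atoms and its own aromatic ring, gives a 1.8-fold lower number from compound 2 to compound 4 (0.24 log units; within the scatter). So in this assay this aromatic carbon can carry a much larger group, including a whole extra ring, with no change beyond the scatter. No measurement shown bears on the reason for this.

As far as these compounds go, what remains open is whether a plain phenyl group, without the trifluoromethyl, would give a similar number. It is also unclear how an amine or a carboxylic acid in place of the trifluoromethyl would fare.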